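A few compounds are considered here, and "the series" means these few. Any claim that something is new, unique, unknown or untested is made for them only; others in the source may bear on it.

Measured compounds: compound 1 `Cc1ncccc1OC[C@@H]1C[C@H]2C[C@H]2N1C`, 231 nM; compound 2 `CN1[C@H](COc2cccnc2)C[C@H]2C[C@H]21`, 5.5 nM.

In an assay on CHO-K1 cells for displacement of a labelled ligand from Neuronal acetylcholine receptor; alpha4/beta2 (Homo sapiens), read by scintillation counting (a lower number here means a stronger inhibitor, a higher number a weaker inhibitor), compound 2 gives 5.5 nM, the lowest of the two numbers measured; the nearest is compound 1, which gives 231 nM. Among the compounds with values here, the single step measured so far, a 42-fold lower number from compound 1 to compound 2 (1.62 log units; beyond the scatter), shows that removing a substituent from an aromatic carbon of the shared core lowered the number by a large margin.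

Compound 3 `CN1[C@H](COc2cccnc2Cl)C[C@H]2C[C@H]21` carries chloro in place of hydrogen on an aromatic carbon, sitting next to the ring nitrogen and ortho to a group of 9 heavy atoms. Within the data shown here, no measured pair tests a chloro on this ring; the only step that bears on a substituent on an aromatic carbon is a 42-fold lower number from compound 1 to compound 2 (1.62 log units; beyond the scatter), where adding one gave a large rise. Compound 3 is therefore expected to show a large rise in this assay, of about a 15-fold higher number from compound 2 to compound 3 (1.16 log units; beyond the scatter), possibly somewhat smaller than the methyl step because compound 1 gave 231 nM with a different group.

Compound 3 is estimated at 80 nM, with a range of 20 nM to 400 nM.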

Compound 3, inhibition constant: 28.1 nM
Estimate against measurement, compound 3: 2.8-fold (0.45 log units) above; the measured number falls inside the stated range.
By their numbers in this assay, from the lowest: compound 2; then compound 3; then compound 1.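

In this assay, a second group now tests this place: chloro on an aromatic carbon, next to the ring nitrogen and ortho to a group of 9 heavy atoms, gives a 5.1-fold higher number from compound 2 to compound 3 (0.71 log units; beyond the scatter), so the rise over hydrogen seen here is not confined to methyl. The two substituents are not interchangeable, as chloro in place of methyl gives an 8.2-fold lower number from compound 1 to compound 3 (0.91 log units; beyond the scatter), which means the size of the rise depends on which group enters, while hydrogen in compound 2 still gives the lowest number of the three. Nothing available accounts for the difference between chloro and methyl at this place.

With only hydrogen, methyl and chloro compared here, the compounds shown leave open whether a fluoro, methoxy or amino group at this place would stay close to hydrogen or fall nearer to chloro or methyl. They also leave open whether chloro on one of the other aromatic carbons of this ring would bring a rise of similar size.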